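Chloro in Place of Fluoro, Measured Once, Expected Again

The source may hold more compounds than are shown below. What is called first, only, known or untested is meant among the compounds shown, and "the series" means these compounds.

Compound 1 `Cc1oc2c([C@H]3CCN(C)C[C@H]3O)c(O)cc(O)c2c(=O)c1C(O)c1ccc(Cl)cc1`: 2% in a functional assay on HL-60 cells (Homo sapiens) for inhibition, read by MTT assay, with a stated time of 48 h, tested at 10 uM; on this read-out higher numbers stand for more inhibition of growth at the one concentration tested and lower numbers for less inhibition of growth
Compound 2 `Cc1oc2c([C@H]3CCN(C)C[C@H]3O)c(O)cc(O)c2c(=O)c1C(O)c1ccc(F)cc1`: 30% in this assay
Compound 3 `CN1CC[C@H](c2c(O)cc(O)c3c(=O)cc(/C=C/c4ccccc4F)oc23)[C@H](O)C1`: 62% in this assay

Compound 2 and compound 1 share one core and differ in a single place: chloro in place of fluoro on an aromatic carbon. That exchange is measured, and it made a number 28 percentage points lower from compound 2 to compound 1 (beyond the scatter). Compound 3 sits on a different core; how it differs from compound 2 is not broken down here, since the two differ in more than one place. In this assay compound 3 gives the highest of the three numbers, and its gap to compound 2 and to compound 1 lies beyond the scatter.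

Compound 4 `CN1CC[C@H](c2c(O)cc(O)c3c(=O)cc(/C=C/c4ccccc4Cl)oc23)[C@H](O)C1` has not yet been measured. It differs from compound 3 by chloro in place of fluoro on an aromatic carbon. Among the compounds with values here, this is the same kind of change as the one from compound 2 to compound 1, but not the same change: there the aromatic carbon was para to a large group, here it is ortho to a large group, and the surrounding core is another one. Resting on the measured drop from compound 2 to compound 1, compound 4 is expected to fall below compound 3 by a number 22 percentage points lower from compound 3 to compound 4 (beyond the scatter), with a wider margin because a number 28 percentage points lower from compound 2 to compound 1 (beyond the scatter) was seen on another core and at another place. The estimate for compound 4 in this assay is 40%, with a range from 15% to 65%.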

Compound 4, percent growth inhibition at one concentration: 61%
For compound 4 the middle estimate is 21 percentage points below the measured one, and the stated range covers the measured number.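

In this assay, chloro in place of fluoro on an aromatic carbon ortho to a large group gave a number 1 percentage points lower from compound 3 to compound 4 (within the scatter), so on the core of compound 3 the exchange left the growth-inhibition reading without a change that can be told from scatter. Set beside the earlier step, this shows that the size of the step did not carry from one core to the other in this series, and that the drop seen on the first core cannot be assumed on the second: the same change on two cores in this assay, a number 28 percentage points lower (beyond the scatter) from compound 2 to compound 1 and a number 1 percentage points lower (within the scatter) from compound 3 to compound 4, 27 percentage points apart, beyond the scatter of two such steps. It does not show what sets the two steps apart, since the two pairs differ both in the core and in where the halogen sits, and two pairs at one concentration in one cell line give no rule for any further core.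

The compounds shown leave open whether the step follows the core or the place of the halogen, a question that the same exchange at both places on a single core would settle. They also leave open how a bromo or a methoxy group would read at the place held by fluoro and chloro in compound 3 and compound 4.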